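The source may report more compounds than this note shows. Statements on the series, on what has been measured and on what is new or still open speak of the compounds shown alone.

Measured so far:
Compound 1, `OCCn1nc(-c2cc3ccccc3[nH]2)nc1SCc1ccccc1`: 14.6 ug/mL
Compound 2, `CC(=O)N[C@@H]1[C@@H](OC(C)=O)[C@H](OC(C)=O)[C@@H](COC(C)=O)O[C@H]1n1nc(SCc2ccccc2)nc1-c1cc2ccccc2[nH]1`: 15.9 ug/mL

Of the compounds shown here, two have been tested in a functional assay on MCF7 cells (Homo sapiens) for antiproliferative activity, read by sulforhodamine B assay, with a stated time of 48 h; a lower number here means a stronger inhibitor, a higher number a weaker inhibitor. Compound 1 has the smaller of the two numbers, but the gap to compound 2, which carries a sugar-like group on the same core, falls within the usual scatter of this kind of measurement, so the two cannot be told apart on these data alone.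

The next compound, compound 3, `C=CCn1nc(-c2cc3ccccc3[nH]2)nc1SCc1ccccc1`, keeps the shared core and the benzylthio group of compound 1 and changes only the chain on the ring nitrogen: vinyl in place of hydroxymethyl on a saturated chain carbon bound to an aromatic nitrogen. Going by the values given here, no pair of measured compounds shows what such a change does, so the step has to be guessed. Swapping a small polar end for a small hydrocarbon end is expected to shift the result little, and the step of a 1.2-fold lower number from compound 1 to compound 3 (0.09 log units; within the scatter) is estimated to stay within the scatter. For compound 3 the expected value in this assay is 12 ug/mL, with a plausible range from 5 ug/mL to 30 ug/mL.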

Compound 3, half-maximal inhibitory concentration: 15.5 ug/mL
The estimate for compound 3 lay 1.3-fold (0.11 log units) below the measured number, within the range that was stated.
By their numbers in this assay, from the lowest: compounds 1, 3 and 2 (each within the scatter of the next).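

In this assay, vinyl in place of hydroxymethyl on a saturated chain carbon bound to an aromatic nitrogen gives a 1.1-fold higher number from compound 1 to compound 3 (0.03 log units; within the scatter). Going by these compounds alone, this is the first measured pair to isolate this position, and it shows that 2-hydroxyethyl and allyl cannot be told apart here, even though the hydrogen-bond donor and acceptor counted in hydroxymethyl are absent from vinyl. No available evidence explains this result.

The compounds shown leave open whether an amine, a carboxylic acid or a longer chain at this place would give a number beyond the scatter. They also leave open whether the same swap would give a similar result with a group other than benzylthio on the shared core.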